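Cytotoxicity of a triazole-linked series on human T-cells

The source may report more compounds than this note shows. Statements on the series, on what has been measured and on what is new or still open speak of the compounds shown alone.

Compound 1: `Cc1cc(C)c(Oc2cc(Nc3ccc(C#N)cc3)ncc2C(=O)NCc2cn(Cc3ccc(F)cc3)nn2)c(C)c1`, in an ADME assay on MT4 cells (Homo sapiens) for cytotoxicity, read by MTT assay, with a stated time of 5 days (on this read-out higher numbers stand for lower toxicity in this test and lower numbers for higher toxicity in this test), compound 1 gives >= 153000 nM, which is a limit of the assay and not a number.
Compound 2: `Cc1cc(C)c(Oc2cc(Nc3ccc(C#N)cc3)ncc2C(=O)NCc2cn(CC(=O)N3CCOCC3)nn2)c(C)c1`, in this assay compound 2 gives 181000 nM.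

Compound 2 holds the only number shown in this assay; the other value is a limit (the limit of >= 153000 nM in this assay, at which 1 of the 2 values shown sits). Compound 3 is `Cc1cc(C)c(Oc2cc(Nc3ccc(C#N)cc3)ncc2C(=O)NCc2cn(CCCO)nn2)c(C)c1`, differing from compound 2 by 2-hydroxyethyl in place of (morpholin-4-yl)carbonyl on a saturated chain carbon bound to an aromatic nitrogen. Going by the values given here, the one measured step, a step that the limit leaves unreadable from compound 1 to compound 2, cannot be read in size, so no measured step bears on this change. Compound 3 is therefore expected to stay near compound 2, with a 1.0-fold lower number from compound 2 to compound 3 (0.00 log units; within the scatter) meaning a step within the scatter; the estimate for compound 3 is 180000 nM, ranging from 90000 nM to 400000 nM.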

Compound 3, half-maximal cytotoxic concentration: 25200 nM
Beside the measured number, compound 3's estimate is 7.1-fold (0.85 log units) above it; the measured number lies below the stated range.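

In this assay, the group on a saturated chain carbon bound to an aromatic nitrogen now proves able to shift the read-out: 2-hydroxyethyl in place of (morpholin-4-yl)carbonyl gives a 7.2-fold lower number from compound 2 to compound 3 (0.86 log units; beyond the scatter), towards higher toxicity in this test. 2-hydroxyethyl in place of 4-fluorophenyl gives an at least 6.0-fold lower number from compound 1 to compound 3 (0.78 log units; beyond the scatter). The value of compound 1 is a limit of the assay and not a number: the limit of >= 153000 nM in this assay, at which 1 of the 3 values shown sits.

The compounds shown leave open whether a methoxy group or an amine at the end of the same chain would read like compound 3 or like compound 2.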